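Swapping a dichlorophenyl for a dimethylphenyl

The source may hold more compounds than are shown below. What is called first, only, known or untested is meant among the compounds shown, and "the series" means these compounds.

Measured compounds:
Compound 1 `Cn1ccnc1[C@@H](CC(=O)O)c1ccc(OCc2cccc(-c3ccc(Cl)cc3Cl)c2)cc1`: 69 nM
Compound 2 `Cc1cc(Cl)ccc1-c1cc(COc2ccc([C@H](CC(=O)O)c3nccn3C)cc2)ccc1C`: 97 nM

In an assay on CHO cells for agonist activity at Free fatty acid receptor 1 (Homo sapiens), read by luminescence, with a stated time of 20 s, in the presence of a further agent that is not named here (a higher number here means that more compound is needed for the effect, a lower number that less compound is needed), compound 1 gives 69 nM, the lowest of the two numbers, while compound 2 gives 97 nM, and the two lie within the scatter of each other, so no order can be read from them. Compound 3 `Cc1cccc(C)c1-c1cccc(COc2ccc([C@H](CC(=O)O)c3nccn3C)cc2)c1` has not been measured. It differs from compound 1 in one place: 2,6-dimethylphenyl in place of 2,4-dichlorophenyl on an aromatic carbon. For the measured compounds named here, no step between measured compounds isolates this change, so the expectation rests on the closeness of compound 1 and compound 2 alone. A step of a 1.6-fold higher number from compound 1 to compound 3 (0.20 log units; within the scatter) is expected, with no clear direction beyond the scatter. Compound 3 is estimated at 110 nM, in the range 40 nM to 300 nM.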

Compound 3, half-maximal effective concentration: 58 nM
For compound 3 the middle estimate is 1.9-fold (0.28 log units) above the measured one; measured number inside the range.
By their numbers in this assay, from the lowest: compounds 3, 1 and 2 (each within the scatter of the next).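

For the compounds shown here, this is the first comparison that isolates a single place: in this assay the step is a 1.2-fold lower number from compound 1 to compound 3 (0.08 log units; within the scatter) and lies within the scatter. At this aromatic carbon, then, 2,6-dimethylphenyl and 2,4-dichlorophenyl cannot be told apart, even though two carbon-bound methyl groups replace two chlorines and the heavy-atom count stays the same. No measurement shown here offers an explanation for this result. Still open, from the compounds shown here alone, is how a plain phenyl, or a ring bearing methoxy or trifluoromethyl groups, would read at this place.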